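The compounds below may be only part of what the source reports. "The series", "measured", "known", "first", "only" and "open" are said of these compounds alone.

Working notes on the series. Compound 1 `Cc1cc(-c2ccsc2)cn2c(CSCCc3ccccc3)cnc12` is the reference point. In an ADME assay on HEL cells (Homo sapiens) for cytotoxicity, with a stated time of 3 days (on this read-out higher numbers stand for lower toxicity in this test and lower numbers for higher toxicity in this test), compound 1 gives > 50 ug/mL, which is a limit of the assay and not a number. Compound 2 `Cc1cc(I)c2ncc(CSCCc3ccccc3)n2c1` is the second measured member. In this assay compound 2 gives > 50 ug/mL, again a limit rather than a number. Going by the values given here, compound 1 therefore stands only at a limit, and the one further value shown is a limit as well; no step between measured compounds can be drawn from these two. The picture is summed up by the limit of > 50 ug/mL in this assay, at which 2 of the 2 values shown sit.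

Compound 3 `Cc1cc(-c2ccc(C#N)cc2)cn2c(CSCCc3ccccc3)cnc12` is not yet measured. It differs from compound 1 by 4-cyanophenyl in place of thiophen-3-yl on an aromatic carbon, in words 4-cyanophenyl in place of thiophen-3-yl on an aromatic carbon. With both measured values sitting at the limit, no direction for the move into compound 3 can be read from the data, and the expectation is a step of none beyond the scatter, with the read-out most likely reported once more as a limit. The estimated step of a number no higher from compound 1 to compound 3 (the limit leaves the size open) is thus expected to be flat. For compound 3 the expected value in this assay is 50 ug/mL, with a range from 25 ug/mL to 100 ug/mL.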

Compound 3, half-maximal cytotoxic concentration: 10.6 ug/mL
Beside the measured number, compound 3's estimate is 4.7-fold (0.67 log units) above it; the measured number lies below the stated range.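

In this assay, 4-cyanophenyl in place of thiophen-3-yl gives an at least 4.7-fold lower number from compound 1 to compound 3 (0.67 log units; beyond the scatter), so this aromatic carbon, two atoms from the ring nitrogen, is not indifferent to what it carries, which the two earlier limits could not show. From the compounds shown here alone, compound 1 gives > 50 ug/mL, which is a limit of the assay, so the step has a lower bound and its full size stays open. Compound 3 is the only compound shown with a read number, and the rest of the picture stays at the limit: the limit of > 50 ug/mL in this assay, at which 2 of the 3 values shown sit.

The change replaces a five-membered ring holding sulfur with a six-membered ring of carbon only and brings in a nitrile at the same time, so the compounds shown cannot say which part carries the step, and they give no reason for it. A plain phenyl at this carbon would separate the ring from the nitrile, while an amine, a carboxylic acid or a longer chain there would show whether the lower number in this read-out extends beyond 4-cyanophenyl.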